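The source may hold more compounds than are shown below. What is called first, only, known or untested is meant among the compounds shown, and "the series" means these compounds.

Measured compounds:
- Compound 1, `c1ccc2c(-c3nnc(-c4ccncc4)o3)c[nH]c2c1`: > 1000000 nM
- Compound 2, `COc1cc(-c2nnc(-c3c[nH]c4ccccc34)o2)ccc1OCc1ccccc1`: > 1000000 nM

Both values come from a functional assay on MDA-MB-231 cells (Homo sapiens) for cytotoxicity, read by MTT assay; on this read-out lower numbers stand for stronger inhibition and higher numbers for weaker inhibition. For compound 1 the figure > 1000000 nM is a limit of the assay and not a measured number. For compound 2 the figure > 1000000 nM is likewise only a limit. Compound 1 therefore stands at the edge of what this assay can report, and the limit of > 1000000 nM in this assay, at which 2 of the 2 values shown sit, says the same of every value gathered here, so no ranking between the two measured compounds is possible.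

Compound 3, `FC(F)(F)c1nnc(-c2c[nH]c3ccccc23)o1`, is not yet measured. It differs from compound 1 in one place: trifluoromethyl in place of pyridin-4-yl on an aromatic carbon. Among the compounds with values here, no step between two measured compounds is available to say how this assay responds to such a change, so the expected size of the step rests only on the two limits already seen.

Given that both measured compounds sit at the limit, compound 3 is expected to show little change, with the step of an at least 1.6-fold lower number from compound 1 to compound 3 (0.22 log units; that floor lies within the scatter) estimated as no more than the scatter. The estimate for compound 3 is 600000 nM, within a range from 100000 nM to 3000000 nM.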

Compound 3, half-maximal inhibitory concentration: > 1000000 nM
Compound 3 was reported as a limit (the forecaster's own chance of this, stated with the estimate: 70%); at least 1.6-fold (0.22 log units) between middle value and limit.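

In this assay compound 3 gives > 1000000 nM, which is a limit and not a number. Swapping pyridin-4-yl in compound 1 for trifluoromethyl in compound 3 therefore gives no readable step, because every value sits at the same limit: the limit of > 1000000 nM in this assay, at which 3 of the 3 values shown sit.

As far as these compounds go, whether either group changes cytotoxicity, and whether this shared core can reach a measurable value in this assay at all, stays open.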